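A few compounds are considered here, and "the series" means these few. Any claim that something is new, unique, unknown or untested is made for them only; others in the source may bear on it.

Series notes: cytotoxicity on the shared core of compound 1 `O=C1c2cccnc2C(=O)N1c1ccc(Cl)cc1`. In an ADME assay on Vero cells (Chlorocebus sabaeus) for cytotoxicity (on this read-out higher numbers stand for weaker inhibition and lower numbers for stronger inhibition), compound 1 gives 92000 nM. Compound 3 `CC(C)c1cccc(C(C)C)c1N1C(=O)c2cccnc2C1=O` gives 21000 nM in this assay, a lower number than compound 1 and beyond the scatter. Compound 2 `COc1ccc(CN2C(=O)c3nccnc3C2=O)cc1OC` reaches only a limit in this assay, > 100000 nM, and that is the whole of what is known of it; the relevant fact here is the limit of > 100000 nM in this assay, at which 1 of the 3 values shown sits. Compound 1 thus holds the highest of the two measured numbers, with compound 3 as its nearest neighbour.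

The next compound, compound 4 `O=C1c2cccnc2C(=O)N1c1ccc(C(F)(F)F)cc1`, differs from compound 1 in a single place: trifluoromethyl in place of chloro on an aromatic carbon. Among the measured compounds shown here, no measured pair in the set shares this change, so no step can be read off for it. The expectation is therefore that the step from compound 1 to compound 4 stays within the usual scatter, in either direction, with nothing to set a size to it: a 1.2-fold lower number from compound 1 to compound 4 (0.06 log units; within the scatter) is the expected step. On this basis compound 4 is estimated at 80000 nM in this assay, with an expected range from 30000 nM to 200000 nM. A limit rather than a number is also a fair prospect for compound 4, given how close compound 1 already sits to it.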

Compound 4, half-maximal inhibitory concentration: 87000 nM
Compound 4: middle estimate off by 1.1-fold (0.04 log units), on the low side; the range from low to high includes it.
By their numbers in this assay, from the lowest: compound 3; then compounds 4 and 1 (each within the scatter of the next). At a limit, above all of these: compound 2.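

Among the compounds shown here, at this place, on an aromatic carbon of a six-membered aromatic ring of carbon only and para to a large group, trifluoromethyl in place of chloro gives a 1.1-fold lower number from compound 1 to compound 4 (0.02 log units; within the scatter) in this assay, the only step that can be read so far. The entering group has 4 heavy atoms against 1 for the leaving group, neither has hydrogen-bond donors or acceptors, and in this one pair the exchange leaves the two values within the scatter of each other. Compound 4 returns a number, and among the compounds shown a limit of the assay rather than a number stands for compound 2 alone: the limit of > 100000 nM in this assay, at which 1 of the 4 values shown sits.

From the compounds shown here alone, whether an amine, a carboxylic acid or a longer chain at this same place would shift the number beyond the scatter stays open, as does whether trifluoromethyl in place of chloro would give a similar step on another compound of the series. A single pair sets no pattern beyond compounds 1 and 4, and it gives no cause for the size of this step.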